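A few compounds are considered here, and "the series" means these few. Any claim that something is new, unique, unknown or untested is made for them only; others in the source may bear on it.

Compound 1 `Cc1cnc2[nH]c(-c3cccc(F)c3)cc(=O)c2c1` is the reference point of this small set. In a functional assay on MDA-N cells (Homo sapiens) for antiproliferative activity (on this read-out lower numbers stand for stronger inhibition of growth and higher numbers for weaker inhibition of growth), compound 1 gives 11.8 nM, the lowest of the two numbers reported. Compound 3 `Cc1cc(C)c2c(O)cc(-c3ccc4ccccc4c3)nc2n1` gives 3240 nM in this assay, a gap from compound 1 that lies beyond the scatter. Compound 2 `Cc1ccc2c(O)cc(-c3cccc(Cl)c3)nc2n1` reaches only a limit of this assay, > 100000 nM (the limit of > 100000 nM in this assay, at which 1 of the 3 values shown sits). Compound 4 `Cc1cnc2[nH]c(-c3cccc(Cl)c3)cc(=O)c2c1` has not yet been measured; it differs from compound 1 by a single change, (chloro in place of fluoro on an aromatic carbon). Among the compounds with values here, no measured pair shows this swap, so the step is expected to be modest: an estimated 1.2-fold lower number from compound 1 to compound 4 (0.07 log units; within the scatter), with no clear direction beyond the scatter. Compound 4 is therefore expected to give about 10 nM in this assay, within a range from 3 nM to 40 nM.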

Compound 4, concentration for 50% growth inhibition: > 100000 nM
Compound 4: only a limit was reported; the forecaster's own chance of this, stated with the estimate: 2%; middle value at least 10000-fold (4.00 log units) from the limit.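

Within the data shown here, on this aromatic carbon, meta to a large group, the earlier compounds gave no one-place comparison; now, with the core of compound 1 kept, chloro in place of fluoro gives an at least 8400-fold higher number from compound 1 to compound 4 (3.92 log units; beyond the scatter). So one atom at this position can decide between strong and undetectable inhibition of growth. The true size of the step remains unknown because compound 4 reaches only a limit in this assay: the limit of > 100000 nM in this assay, at which 2 of the 4 values shown sit.

The compounds shown leave open whether a methoxy group or an amine at this position would behave like fluoro or like chloro. They also leave open why this single swap has so large an effect.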